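The source may hold more compounds than are shown below. What is called first, only, known or untested is meant among the compounds shown, and "the series" means these compounds.

Within the data shown here, compound 3 `COc1cc(/C=C/C(=O)OCCSc2nc(-c3ccc(S(C)(=O)=O)cc3)n(-c3ccc(C)cc3)n2)ccc1OC(C)=O` sits at the highest of the three numbers measured so far in a functional assay on PC-3 cells (Homo sapiens) for antiproliferative activity, read by MTT assay, with a stated time of 72 h (on this read-out higher numbers stand for weaker inhibition and lower numbers for stronger inhibition), where compound 3 gives 15500 nM. Its nearest neighbour is compound 1 `CC(=O)Oc1ccc(/C=C/C(=O)OCCSc2nc(-c3ccc(S(C)(=O)=O)cc3)n(-c3ccc(C(F)(F)F)cc3)n2)cc1OC(C)=O`, which in this assay gives 14500 nM; the furthest is compound 2 `COc1cc(/C=C/C(=O)OCCSc2nc(-c3ccc(S(C)(=O)=O)cc3)n(-c3ccc(F)cc3)n2)ccc1OC(C)=O`, which gives 12800 nM. All three numbers lie within the usual scatter of one another, so none of the three can be called stronger or weaker than the others.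

The step from compound 3 to compound 4 `COc1cc(/C=C/C(=O)OCCSc2nc(-c3ccc(S(C)(=O)=O)cc3)n(-c3ccc(C(F)(F)F)cc3)n2)ccc1OC(C)=O` is trifluoromethyl in place of methyl on an aromatic carbon. Compound 4 has not yet been measured.

Among the measured compounds shown here, only one measured step changes the same aromatic carbon: a 1.2-fold higher number from compound 2 to compound 3 (0.08 log units; within the scatter). For the measured compounds named here, compound 1 also carries a trifluoromethyl group on that ring, but it differs from compound 3 in a second place as well, so its value shows only that a trifluoromethyl compound and a methyl compound give numbers within the scatter. The one clean step gave no movement beyond the scatter, and nothing among these compounds points to a larger effect from the trifluoromethyl group.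

The expectation is therefore a change of a 1.1-fold lower number from compound 3 to compound 4 (0.03 log units; within the scatter), within the scatter. Compound 4 is estimated at 14500 nM, with a range from 7000 nM to 30000 nM.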

Compound 4, half-maximal inhibitory concentration: 9810 nM
Compound 4: middle estimate off by 1.5-fold (0.17 log units), on the high side; the range from low to high includes it.
By their numbers in this assay, from the lowest: compounds 4, 2, 1 and 3 (each within the scatter of the next).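

At the aromatic carbon para to a large group, three groups can now be compared directly in this assay: trifluoromethyl in place of methyl (a 1.6-fold lower number from compound 3 to compound 4 (0.20 log units; within the scatter)) and trifluoromethyl in place of fluoro (a 1.3-fold lower number from compound 2 to compound 4 (0.12 log units; within the scatter)), alongside the earlier step from fluoro to methyl (a 1.2-fold higher number from compound 2 to compound 3 (0.08 log units; within the scatter)), so fluoro, methyl and trifluoromethyl cannot be told apart at this position, and each clean step here stays within the usual scatter. A second place also gets its first clean comparison, since methyl in place of acetyl on an oxygen on an aromatic ring (a 1.5-fold lower number from compound 1 to compound 4 (0.17 log units; within the scatter)) likewise shows no movement beyond the scatter, which means the earlier comparison of the two trifluoromethyl compounds can now be read as a single change. Nothing available gives a reason for any of these numbers.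

Still open, from the compounds shown here alone, is whether a different kind of group at this position, such as an amine, a carboxylic acid or a longer chain, would move the number beyond the scatter. The compounds shown also leave open what a free hydroxyl would do on the oxygen that carries the methyl or acetyl group.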